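Methyl in place of hydrogen on the ester chain

A few compounds are considered here, and "the series" means these few. Any claim that something is new, unique, unknown or untested is made for them only; others in the source may bear on it.

Of the compounds shown here, two sharing one core have been measured in an assay on HEK293 cells for displacement of a labelled ligand from adenosine receptor A2b (Homo sapiens), read by radioligand binding, with a stated time of 30 min, tested at 1 uM; a lower number here means less inhibition, a higher number more inhibition at the concentration tested (going by the name of the read-out). Compound 1 `CC1=C(C(=O)OC(C)C(F)(F)F)C(c2ccoc2)NC(=O)N1` gives 23% in this assay. Compound 2 `CC1=C(C(=O)OCC(F)(F)F)C(c2ccsc2)NC(=O)N1` gives 24% in this assay, the higher of the two numbers, though its nearest neighbour, compound 1, lies only a little below it and the two values sit within the scatter of each other, so no order between them can be read.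

Compound 3 `CC1=C(C(=O)OC(C)C(F)(F)F)C(c2ccsc2)NC(=O)N1` has not yet been measured in this assay. It differs from compound 2 in one place: methyl in place of hydrogen on a saturated chain carbon bound to an oxygen next to a carbonyl group and a saturated chain carbon. Compound 1 already carries this 1-(trifluoromethyl)ethyl ester and gives a value close to that of compound 2, which suggests that the ester chain alone does not move the number far here.

On that basis no step beyond the scatter is expected in this assay: the estimate means a step of a number 1 percentage points higher from compound 2 to compound 3 (within the scatter). Compound 3 is therefore expected to give about 25% in this assay, with a range from 10% to 40%.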

Compound 3, a percentage reported as inhibition, at one concentration (the size of the read-out at that concentration, not a potency): 1%
For compound 3 the middle estimate is 24 percentage points above the measured one; the measured number lies below the stated range.
By their numbers in this assay, from the lowest: compound 3; then compounds 1 and 2 (each within the scatter of the next).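

Measured in this assay methyl in place of hydrogen on the saturated chain carbon bound to the ester oxygen brings a number 23 percentage points lower from compound 2 to compound 3 (beyond the scatter) and so is not a neutral change when thiophen-3-yl is present. With the 1-(trifluoromethyl)ethyl ester held constant, thiophen-3-yl in place of furan-3-yl brings a number 22 percentage points lower from compound 1 to compound 3 (beyond the scatter) and shows that this ester does not read the same with both rings. The two earlier compounds differ in two places, so their closeness could not reveal either step, and the effect of the ester chain here depends on the ring it is paired with. No measurement given here bears on the reason for these two steps.

The compounds shown leave open whether the methyl step would also appear with furan-3-yl on the shared core, since only the 1-(trifluoromethyl)ethyl ester is shown with that ring. They also leave open how this assay would respond to a longer chain on the ester, such as 3,3,3-trifluoropropyl, or to a phenyl ring in place of thiophen-3-yl.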